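Acyl group change on the shared core: working notes

The source may report more compounds than this note shows. Statements on the series, on what has been measured and on what is new or still open speak of the compounds shown alone.

Measured so far in a functional assay on HeLa cells (Homo sapiens) for cytotoxicity, read by MTT assay, with a stated time of 72 h; a higher number here means a weaker inhibitor, a lower number a stronger inhibitor:
- compound 1 `O=C(COc1ccccc1)Nc1nnc(-c2cccc(O)c2O)s1`: 117000 nM
- compound 2 `O=C(Nc1nnc(-c2cccc(O)c2O)s1)c1ccccc1`: 21800 nM

Of the two measured compounds, compound 2 has the lower number, at 21800 nM. The next compound is compound 3 `CC(=O)Nc1nnc(-c2cccc(O)c2O)s1`, which keeps the shared core and differs at one place: methyl in place of phenyl on a carbonyl carbon. This is methyl in place of phenyl on a carbonyl carbon.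

Going by the values given here, one measured step bears on this change: a 5.4-fold lower number from compound 1 to compound 2 (0.73 log units; beyond the scatter). It is modest and involves phenyl in place of phenoxymethyl at the same place. It shows that the group on the carbonyl carbon can move the number in this assay. However, both measured groups contain a ring, and no data yet cover a group without one, so any extension to methyl is uncertain. Of the two groups measured, phenyl gave the lower number, which points to a rise on losing it rather than a further fall.

The expected change is modest and upward, with an estimated 2.5-fold higher number from compound 2 to compound 3 (0.40 log units; beyond the scatter). For compound 3 the estimated value is 55000 nM, with an expected range of 18000 nM to 170000 nM.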

Compound 3, half-maximal inhibitory concentration: 177000 nM
Estimate against measurement, compound 3: 3.2-fold (0.51 log units) below; the whole stated range lies below it.
By their numbers in this assay, from the lowest: compound 2; then compounds 1 and 3 (each within the scatter of the next).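

The result shows that in this assay the phenyl on the carbonyl carbon matters when it is lost outright: methyl in place of phenyl gives an 8.1-fold higher number from compound 2 to compound 3 (0.91 log units; beyond the scatter) and leaves compound 2 with the lowest number of the three. The series now also covers a group with no ring at this place, and hydrogen in place of phenoxy on the saturated chain carbon gives a 1.5-fold higher number from compound 1 to compound 3 (0.18 log units; within the scatter) and so separates neither compound from the other, which means that a ring somewhere in the group does not by itself go with a lower number, with compound 1 standing against that reading. Nothing available explains why phenyl differs from the other two groups.

As far as these compounds go, it remains open whether the lower number of compound 2 needs an aromatic ring on the carbonyl carbon or would also appear with cyclohexyl, and whether chlorine or methoxy on the phenyl would move the number further. Also open, from the compounds shown here alone, is whether an amine or a carboxylic acid on a longer chain at this place would separate from compound 1 and compound 3.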